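The source may hold more compounds than are shown below. What is called first, only, known or untested is meant among the compounds shown, and "the series" means these compounds.

Compound 1 `Nc1cc(N)c2nc(-c3ccccc3)c(Oc3ccc(Cl)c(Cl)c3)nc2c1` is one of only two compounds for which a measurement in a functional assay on NCI-H522 cells (Homo sapiens) for inhibition, read by sulforhodamine B assay, with a stated time of 48 h (on this read-out lower numbers stand for higher toxicity in this test and higher numbers for lower toxicity in this test), is shown. In this assay compound 1 gives < 100000 nM, which is a limit of the assay and not a number. Compound 2 `CCOC(=O)[C@H](CCC(=O)O)NC(=O)c1ccc(Oc2nc3cc(N)cc(N)c3nc2-c2ccccc2)cc1` is the other measured compound. In this assay compound 2 gives < 100000 nM, again a limit and not a number. Among the compounds with values here, the evidence therefore rests on (the limit of < 100000 nM in this assay, at which 2 of the 2 values shown sit), so compound 1 stands at the same limit as the only other value shown, and no measured step can be read from these two. Compound 3 `COc1ccc(Sc2nc3cc(N)cc(N)c3nc2-c2ccccc2)cc1` differs from compound 1 by (4-methoxyphenyl)sulfanyl in place of 3,4-dichlorophenoxy on an aromatic carbon. With no step between measured compounds shown, no direction beyond the scatter can be claimed for this change. Compound 3 is expected to give about 30000 nM, with a range from 5000 nM to 100000 nM. That estimate means an expected step that the limit leaves unreadable from compound 1 to compound 3, which cannot be checked against a limit.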

Compound 3, concentration lethal to 50% of the cells: < 100000 nM
Compound 3: no number, only a limit; the forecaster's own chance of this, stated with the estimate: 50%; the middle value lies beyond the limit too.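

No step from compound 1 to compound 3 can be read, as each gives only a limit and not a number in this assay: the limit of < 100000 nM in this assay, at which 3 of the 3 values shown sit.

The compounds shown leave open where the true values lie, and whether (4-methoxyphenyl)sulfanyl and 3,4-dichlorophenoxy differ at all in this assay.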